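The compounds below may be only part of what the source reports. "The series", "measured", "known", "first", "only" and "open" are said of these compounds alone.

For the measured compounds named here, in a functional assay (aorta) with Rattus norvegicus as the target (on this read-out lower numbers stand for an effect already at smaller amounts and higher numbers for an effect only at larger amounts of compound), two compounds with the same core have numbers so far. Compound 1 `COc1ccc(-c2nc(/N=C(\N)N(C)C)sc2-c2ccc(OC)cc2)cc1` gives 4.8 uM and compound 2 `COc1ccc(-c2nc(/C=C/C(=O)O)sc2-c2ccc(OC)cc2)cc1` gives 55 uM as the higher of the two numbers. Compound 3 `COc1ccc(-c2nc(C3=CCN(C)CC3)sc2-c2ccc(OC)cc2)cc1` is still unmeasured and differs from compound 2 in one place on the shared core, with a group of 7 heavy atoms (6 carbon, 1 nitrogen; one six-membered non-aromatic ring with 1 hetero atom) in place of a group of 5 heavy atoms (3 carbon, 2 oxygen; no ring), on an aromatic carbon as the counted change. Going by the values given here, the one measured step at this place runs an 11-fold higher number from compound 1 to compound 2 (1.06 log units; beyond the scatter) and it is large. Going to compound 3 removes the 2-carboxyethenyl group, and the group that enters, like the group on compound 1, holds nitrogen and no oxygen. Since compound 1 stands at 4.8 uM in this assay a move toward a lower number is expected, but the two groups otherwise differ and one step is thin evidence, so the size stays uncertain. The expected change is a 4.6-fold lower number from compound 2 to compound 3 (0.66 log units; beyond the scatter) and it may prove smaller than the measured one. Compound 3 is estimated at 12 uM with 3 uM to 45 uM as the expected range.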

Compound 3, concentration for half-maximal effect: 5.9 uM
Beside the measured number, compound 3's estimate is 2.0-fold (0.31 log units) above it, within the range that was stated.
By their numbers in this assay, from the lowest: compounds 1 and 3 (each within the scatter of the next); then compound 2.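

In this assay, swapping the 2-carboxyethenyl group for the six-membered ring that holds nitrogen shifts the number well beyond the scatter (a 9.3-fold lower number from compound 2 to compound 3 (0.97 log units; beyond the scatter)), so a second nitrogen-bearing group now stands apart from compound 2. The two nitrogen-bearing groups cannot be told apart here (a 1.2-fold higher number from compound 1 to compound 3 (0.09 log units; within the scatter)), although the group on compound 3 has a ring and the group on compound 1 has none, so a ring at this position is not needed to stay clear of compound 2. Nothing given here explains these numbers.

On these data alone, it remains open whether a simple amine or a carboxylic acid placed directly on this aromatic carbon would behave the same way. A longer chain ending in an amine, or the same ring without its double bond, would also test how much of the entering group matters.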